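One Hydroxy Fewer: an Expectation for Compound 3

The compounds below may be only part of what the source reports. "The series", "measured", "known", "first", "only" and "open" are said of these compounds alone.

Two compounds of this series have numbers in a functional assay on K562 cells (Homo sapiens) for antiproliferative activity, read by cell counting, with a stated time of 7 days; a lower number here means a stronger inhibitor, a higher number a weaker inhibitor. Compound 1 `COc1cc(/C=N/NC(=O)c2cc3ccccc3o2)ccc1O` gives 5600 nM in this assay. Compound 2 `O=C(N/N=C/c1c(O)cc(O)cc1O)c1cc2ccccc2o1` gives 64000 nM in this assay, the highest of the two numbers and beyond the scatter away from compound 1. Going by the values given here, no single-place step between the two measured compounds can be drawn, so only their two values can be compared.

Compound 3 `O=C(N/N=C/c1ccc(O)cc1O)c1cc2ccccc2o1` has not been measured in this assay. It differs from compound 2 in one place: hydrogen in place of hydroxy on an aromatic carbon. With no measured step of this kind in the series, the direction can only be guessed from the standing of compound 2, whose 64000 nM leaves room for a lower number without moving outside what compound 1 shows. A modest step is expected, toward a lower number, though it might also stay within the scatter.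

For compound 3 the estimate in this assay is 20000 nM, with a range from 5000 nM to 80000 nM. That estimate means an expected step of a 3.2-fold lower number from compound 2 to compound 3 (0.51 log units; beyond the scatter).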

Compound 3, half-maximal inhibitory concentration: 4300 nM
Compound 3: middle estimate off by 4.7-fold (0.67 log units), on the high side; the measured number lies below the stated range.
By their numbers in this assay, from the lowest: compounds 3 and 1 (each within the scatter of the next); then compound 2.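

In this assay, the series now has its first single-place step, and it is large: hydrogen in place of a hydroxy that is ortho to a large group and meta to two hydroxy groups gives a 15-fold lower number from compound 2 to compound 3 (1.17 log units; beyond the scatter) in a single change. The earlier compounds shown here could not show this, since no single-place step linked them and their two values could not be tied to any one position; now a change beyond the scatter is tied to one aromatic carbon of the ring that carries the hydroxy groups. Nothing available explains the size of this step, so it stands as an observation on this one pair.

The compounds shown leave open what an amine, a fluorine or a carboxylic acid would give on this same carbon, and whether losing either of the two remaining hydroxy groups of compound 2 would give a step of similar size. Going by these compounds alone, they also leave open whether this change would give a similar step on any core other than the one shared by compound 2 and compound 3.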